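The source may report more compounds than this note shows. Statements on the series, on what has been measured and on what is new or still open speak of the compounds shown alone.

Working notes on the series. Going by the values given here, in a functional assay on PC-3 cells (Homo sapiens) for inhibition, read by sulforhodamine B assay, with a stated time of 48 h, tested at 50 uM (on this read-out higher numbers stand for more inhibition of growth at the one concentration tested and lower numbers for less inhibition of growth), compound 1 `COc1ccc([C@@H]2C/C(=N/OCc3cn(-c4ccc(C#N)cc4)nn3)c3cc(CC=C(C)C)c(OC)cc3O2)cc1` gives 50% and compound 2 `COc1ccc([C@@H]2C/C(=N/OCc3cn(-c4cccc(CO)c4)nn3)c3cc(CC=C(C)C)c(OC)cc3O2)cc1` gives 34%, so compound 2 holds the lower of the two numbers so far.

Compound 3 `COc1ccc([C@@H]2C/C(=N/OCc3cn(-c4cc(OC)c(OC)c(OC)c4)nn3)c3cc(CC=C(C)C)c(OC)cc3O2)cc1` carries 3,4,5-trimethoxyphenyl in place of 3-(hydroxymethyl)phenyl on an aromatic nitrogen of the five-membered aromatic ring with 3 nitrogen: 3,4,5-trimethoxyphenyl in place of 3-(hydroxymethyl)phenyl on an aromatic nitrogen.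

Among the compounds with values here, one measured step bears on this change, at the same aromatic nitrogen: a number 16 percentage points lower from compound 1 to compound 2 (beyond the scatter). It shows that exchanging the group there can move the read-out by a modest amount. Within the data shown here, no measured compound carries 3,4,5-trimethoxyphenyl, so that step informs the size better than the direction. Among the measured compounds shown here, with only two numbers available, and compound 2 the lower, a modest step upward in this assay is expected, with low confidence in its direction and no larger than the measured step.

The expected change is a number 10 percentage points higher from compound 2 to compound 3 (within the scatter). For compound 3 the estimated value is 44%, with an expected range of 26% to 62%.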

Compound 3, percent growth inhibition at one concentration: 36%
Compound 3: the middle estimate sits 8 percentage points above what was measured; the range from low to high includes it.
By their numbers in this assay, from the lowest: compounds 2 and 3 (each within the scatter of the next); then compound 1.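

In this assay, 3,4,5-trimethoxyphenyl in place of 3-(hydroxymethyl)phenyl on the aromatic nitrogen gives a number 2 percentage points higher from compound 2 to compound 3 (within the scatter), so these two groups read alike here even though they differ in heavy atoms, hydrogen-bond donors and hydrogen-bond acceptors. Against 4-cyanophenyl, the same 3,4,5-trimethoxyphenyl group gives a number 14 percentage points lower from compound 1 to compound 3 (beyond the scatter), a second modest step at this position, which leaves compound 1 alone at the top of the three and compound 2 and compound 3 together beneath it. No measurement at hand accounts for the separation of compound 1 from the other two.

The three compounds do not settle whether the nitrile of compound 1 sets it apart or whether any other substituent on the phenyl ring would read the same way, and an amine or a carboxylic acid at that place would test this directly. Also open, as far as these compounds go, is whether the aromatic ring on this nitrogen is needed at all, a question that a simple alkyl chain there would address.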